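Thiophene Isomers on a Nucleoside Core: No Measurable Inhibition

A few compounds are considered here, and "the series" means these few. Any claim that something is new, unique, unknown or untested is made for them only; others in the source may bear on it.

Compound 1 `O=c1[nH]cnc2c1c(-c1cccs1)cn2[C@@H]1O[C@H](CO)[C@@H](O)[C@H]1O`: in an ADME assay on BJ cells (Homo sapiens), read by MTT assay, with a stated time of 72 h (on this read-out lower numbers stand for stronger inhibition and higher numbers for weaker inhibition), compound 1 gives > 100000 nM, which is a limit of the assay.
Compound 2 `O=c1[nH]cnc2c1c(-c1ccsc1)cn2[C@@H]1O[C@H](CO)[C@@H](O)[C@H]1O`: in this assay compound 2 gives > 100000 nM, again a limit of the assay.
Compound 3 `CNc1ncnc2c1c(-c1cccs1)cn2[C@@H]1O[C@H](CO)[C@@H](O)[C@H]1O`: in this assay compound 3 gives > 100000 nM, also a limit of the assay.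

All three measured compounds therefore sit at the same point, (the limit of > 100000 nM in this assay, at which 3 of the 3 values shown sit). Compound 1 and compound 2 share one core and differ in a single place: thiophen-3-yl in place of thiophen-2-yl on an aromatic carbon. The step that the two limits leave unreadable from compound 1 to compound 2 cannot be read, since both ends are limits rather than numbers. Compound 3 rests on a second core; the difference between the two cores is not broken down here.

Compound 4 `CNc1ncnc2c1c(-c1ccsc1)cn2[C@@H]1O[C@H](CO)[C@@H](O)[C@H]1O` is not yet measured. It stands to compound 3 exactly as compound 2 stands to compound 1: thiophen-3-yl in place of thiophen-2-yl on an aromatic carbon. The surroundings of the changed position are the same word for word in both pairs, so this is the same change, made on the second core.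

What can be expected for compound 4 rests on two things: compound 3 itself sits at the limit > 100000 nM, and the same change gave no readable movement from the first core, a step that the two limits leave unreadable from compound 1 to compound 2. Compound 4 is therefore expected to remain at the limit, with an estimated step that the limit leaves unreadable from compound 3 to compound 4. The estimated value for compound 4 is 150000 nM, expected to lie between 80000 nM and 500000 nM.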

Compound 4, half-maximal inhibitory concentration: > 100000 nM
Compound 4: a limit, no number (the forecaster's own chance of this, stated with the estimate: 90%); the middle value lies beyond the limit too.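

Compound 4 gives a limit of the assay, as compound 3 does, so the step from thiophen-2-yl to thiophen-3-yl cannot be read here, just as it could not be read between compound 1 and compound 2: the limit of > 100000 nM in this assay, at which 4 of the 4 values shown sit. The compounds shown leave open whether any of them differs from another in this assay and at what concentration, if any, each would inhibit these cells.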